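A few compounds are considered here, and "the series" means these few. Any claim that something is new, unique, unknown or untested is made for them only; others in the source may bear on it.

In an ADME assay on HeLa cells (Homo sapiens) for cytotoxicity, read by crystal violet staining, with a stated time of 24 h (on this read-out lower numbers stand for an effect already at smaller amounts and higher numbers for an effect only at larger amounts of compound), compound 1 `CCCNC(=O)c1ccc([N+](=O)[O-])o1` gives 150000 nM. Within the data shown here, the only other measured compound, compound 2 `CC(C)NC(=O)c1ccc([N+](=O)[O-])o1`, gives 211000 nM, and the two values lie within the scatter of each other. Compound 3 `CN(C)CCCNC(=O)c1ccc([N+](=O)[O-])o1` differs from compound 1 by dimethylamino in place of hydrogen on a saturated chain carbon, three bonds along the chain from an amide-type nitrogen. Among the measured compounds shown here, the single measured step, isopropyl in place of propyl on an amide-type nitrogen, is a 1.4-fold higher number from compound 1 to compound 2 (0.15 log units; within the scatter). It bears only weakly on the new change, as it alters the chain without adding a dimethylamino group. No measurement shows how a dimethylamino group behaves on this chain, so the data give no firm direction, and no shift beyond the scatter is expected, though with wide uncertainty. The expected step is a 1.2-fold lower number from compound 1 to compound 3 (0.06 log units; within the scatter). For compound 3 the estimated value is 130000 nM, with an expected range from 35000 nM to 400000 nM.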

Compound 3, half-maximal effective concentration: 74000 nM
Estimate against measurement, compound 3: 1.8-fold (0.24 log units) above; low and high end bracket the measured number.
By their numbers in this assay, from the lowest: compound 3; then compounds 1 and 2 (each within the scatter of the next).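

In this assay, dimethylamino in place of hydrogen on a saturated chain carbon, three bonds along the chain from an amide-type nitrogen, gives a 2.0-fold lower number from compound 1 to compound 3 (0.31 log units; beyond the scatter). This shows that a change at this chain can move the number beyond the scatter, which isopropyl in place of propyl did not do, with a 1.4-fold higher number from compound 1 to compound 2 (0.15 log units; within the scatter), although the new step is modest and rests on a single pair. Nothing available accounts for the shift.

The compounds shown leave open whether a plain longer chain such as pentyl, carrying no nitrogen, would give a similar step to that of dimethylamino. They also leave open whether a carboxylic acid at this place would move the number in the same direction or the opposite one.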